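The compounds below may be only part of what the source reports. "The series", "measured", "known", "first", "only" and "open" are said of these compounds alone.

Measured in an ADME assay on Vero cells (Chlorocebus sabaeus) for cytotoxicity, read by XTT assay, with a stated time of 72 h; on this read-out lower numbers stand for higher toxicity in this test and higher numbers for lower toxicity in this test:
compound 1, `CC1=C(C(=O)OC(C)(C)C)C(c2cccs2)NC(=O)N1`: > 100000 nM
compound 2, `CCOC(=O)C1=C(C)N(C)C(=O)NC1c1ccc(F)cc1`: "non-toxic" (no number reported)
compound 3, `COC(=O)C1=C(C)NC(=O)NC1c1ccc(F)cc1`: "non-toxic" (no number reported)

Three compounds have been put through this assay, and none of them yields a number in the ordinary sense. Compound 1 is reported only as a limit of the assay, > 100000 nM, which is the limit of > 100000 nM in this assay, at which 1 of the 3 values shown sits. Compound 2 is simply described as "non-toxic" (no number reported). Compound 3 is likewise recorded as "non-toxic" (no number reported), so it stands alongside the other two without a single value of its own. Nothing in this set separates one compound from another beyond the scatter.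

Compound 4, `COC(=O)C1=C(C)N(C)C(=O)NC1c1ccc(F)cc1`, is the untested member. It differs from compound 3 by methyl in place of hydrogen on an amide-type nitrogen in a ring; in words, methyl in place of hydrogen on an amide-type nitrogen in a ring. For the measured compounds named here, no measured step of this kind is available in this assay, so the size of the change cannot be read from a pair of numbers. The expectation is for no shift beyond the scatter, in either direction, since compound 2, which carries the same methylated ring nitrogen, is recorded as "non-toxic" (no number reported).

Compound 4 is therefore expected to give 150000 nM in this assay, with a range from 50000 nM to 500000 nM, most likely reported again only as a limit.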

Compound 4, half-maximal cytotoxic concentration: "non-toxic" (no number reported)
For compound 4 the study gives words and no number; the estimate stays without a comparison.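

Compound 3 and compound 4 are both recorded in this assay only as "non-toxic", without a number, so no step can be read between them. The compounds shown leave open whether methyl in place of hydrogen on an amide-type nitrogen in a ring changes the half-maximal cytotoxic concentration at all, and at what concentration either compound would become toxic.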